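This account rests on a few compounds, and the source may have more. Where it says the series, first, only, none or still open, it means among the compounds named here.

Measured in a functional assay on MCF7 cells (Homo sapiens) for antiproliferative activity, read by MTT assay, with a stated time of 72 h; on this read-out higher numbers stand for weaker inhibition and lower numbers for stronger inhibition:
Compound 1 `Cc1c(C=C(CO)CO)n(C)c(=O)[nH]c1=O`: > 100000 nM, a limit of the assay.
Compound 2 `COc1nc(CC(O)(COC(C)=O)COC(C)=O)c(C)c(OC)n1`: > 100000 nM, a limit of the assay.
Compound 3 `COc1nc(=O)n(C)c(CC(F)(COC(C)=O)COC(C)=O)c1C`: > 100000 nM, a limit of the assay.

On these numbers compound 3 stands at the limit, as do the other two values shown; (the limit of > 100000 nM in this assay, at which 3 of the 3 values shown sit). Within the data shown here, no step between measured compounds that differ in one place is available, so no measured step size can be quoted. Compound 4 `COc1nc(=O)n(C)c(CC(O)(COC(C)=O)COC(C)=O)c1C` differs from compound 3 by hydroxy in place of fluoro on a saturated chain carbon bound to three saturated chain carbons. With every value in this assay sitting at the limit, no step beyond the scatter is expected in either direction, and the step from compound 3 to compound 4 is estimated as a number no higher from compound 3 to compound 4 (the limit leaves the size open). Compound 4 is expected to give about 100000 nM in this assay, within 30000 nM to 300000 nM, most likely reported again only as a limit.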

Compound 4, half-maximal inhibitory concentration: > 100000 nM
Compound 4: a limit, no number; the forecaster's own chance of this, stated with the estimate: 80%; the middle value sits exactly at the limit.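

No step can be read between compound 3 and compound 4, as both stand only as limits in this assay: the limit of > 100000 nM in this assay, at which 4 of the 4 values shown sit.

The compounds shown leave open whether hydroxy or fluoro at this place makes any difference in this assay.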